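This account rests on a few compounds, and the source may have more. Where it says the series, first, only, none or still open, it means among the compounds named here.

Compound 1 `CCCNC(=O)c1cccn1-c1ccc2c(c1)B(O)OC2` and compound 2 `Cc1ccccc1C(=O)c1ccn(-c2ccc3c(c2)B(O)OC3)c1` share one core, and both were run in an ADME assay on L929 cells (Mus musculus) for cytotoxicity, read by resazurin assay, with a stated time of 72 h; a lower number here means a stronger inhibitor, a higher number a weaker inhibitor. For compound 1 the result is a limit of the assay, > 10 ug/mL. For compound 2 the result is also a limit, > 10 ug/mL. Compound 2 thus stands at the limit of > 10 ug/mL in this assay, at which 2 of the 2 values shown sit, so no number of its own separates it from compound 1 in this assay. Compound 3 `CCCC(=O)c1ccn(-c2ccc3c(c2)B(O)OC3)c1` has not yet been measured in this assay. It differs from compound 2 in a single place: propyl in place of 2-methylphenyl on a carbonyl carbon. Among the measured compounds shown here, no step between measured compounds is available to size this change. The step that the limit leaves unreadable from compound 2 to compound 3 is expected to lie within the usual scatter, with compound 3 most likely again reported only as a limit. Compound 3 is estimated at 15 ug/mL, with a range from 7 ug/mL to 40 ug/mL.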

Compound 3, half-maximal inhibitory concentration: > 10 ug/mL
Compound 3 was reported as a limit (the forecaster's own chance of this, stated with the estimate: 75%); the middle value lies beyond the limit too.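

Compound 2 and compound 3 are each reported only as a limit, so no step between them can be read in this assay: the limit of > 10 ug/mL in this assay, at which 3 of the 3 values shown sit.

The compounds shown leave open whether propyl in place of 2-methylphenyl on a carbonyl carbon shifts the result in this assay at all.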